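The compounds below may be only part of what the source reports. "The series", "measured", "known", "first", "only" and "open" are said of these compounds alone.

Among the compounds with values here, compound 1 `C=CCc1cc(C(C)=O)c(O)cc1OCC#N` is one of three compounds measured in an assay on isolated protein for binding affinity to leukotriene B4 receptor 1 (Homo sapiens), tested at 1 uM; a higher number here means more inhibition at the concentration tested (going by the name of the read-out), a lower number less inhibition. There compound 1 gives 2%. Compound 3 `CC(=O)c1cc(C(C)(C)C)c(OCCCCCC(C)(C)C#N)cc1O` gives 2%, the same number at the digits reported, so the two stand together at the low end of the set, within the usual scatter of each other. Compound 2 `CCc1cc(C(C)=O)c(O)cc1OCCCCC(C)(C)C#N` gives 30%, a number well above both and beyond the scatter. Compound 4 `C=CCc1cc(C(C)=O)c(O)cc1OCCCCCCC` has not yet been measured in this assay. It differs from compound 1 in one place: hexyl in place of cyano on a saturated chain carbon bound to an oxygen on an aromatic ring. Within the data shown here, no step between measured compounds shares this change, so its direction is uncertain. A modest rise is nonetheless expected, a number 13 percentage points higher from compound 1 to compound 4 (beyond the scatter). Compound 4 is estimated at 15%, with a range from 0% to 45%.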

Compound 4, a percentage reported as inhibition, at one concentration (the size of the read-out at that concentration, not a potency): 8%
For compound 4 the middle estimate is 7 percentage points above the measured one, within the range that was stated.
By their numbers in this assay, from the lowest: compounds 1, 3 and 4 (each within the scatter of the next); then compound 2.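

In this assay, hexyl in place of cyano on a saturated chain carbon bound to an oxygen on an aromatic ring gives a number 6 percentage points higher from compound 1 to compound 4 (within the scatter). This first step at the position shows that this exchange of a nitrile for an all-carbon chain does not move the read-out beyond the scatter. No evidence is available to explain this result. Going by these compounds, whether a carboxylic acid, an amine or a longer chain in place of hexyl would change the number remains open. So does the source of the higher number for compound 2, which no single-place step connects to the other compounds.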